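This account rests on a few compounds, and the source may have more. Where it says the series, first, only, none or still open, it means among the compounds named here.

Four tetrabrominated benzimidazole-like compounds, all carrying a nitrile-ended chain on a ring nitrogen, were compared in a functional assay on MCF7 cells (Homo sapiens) for cytotoxicity, read by MTT assay, with a stated time of 24 h, tested at 50 uM; on this read-out higher numbers stand for a weaker effect at the one concentration tested and lower numbers for a stronger effect. Compound 1 `Cc1nc2c(Br)c(Br)c(Br)c(Br)c2n1CC#N` gives 11%. Compound 2 `Cc1nc2c(Br)c(Br)c(Br)c(Br)c2n1CCC#N` gives 15%. Compound 3 `N#CCCCCn1cnc2c(Br)c(Br)c(Br)c(Br)c21` gives 18%. Among the measured compounds shown here, the one counted change among the measured compounds, (cyano in place of cyanomethyl on a saturated chain carbon bound to an aromatic nitrogen), made a step of a number 4 percentage points lower from compound 2 to compound 1 (within the scatter), which lies within the scatter. The difference between the cores of compound 2 and compound 3 is not broken down here.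

Compound 4 `N#CCCCn1cnc2c(Br)c(Br)c(Br)c(Br)c21` is not yet measured in this assay. It differs from compound 3 by cyano in place of cyanomethyl on a saturated chain carbon, three bonds along the chain from an aromatic nitrogen. For the measured compounds named here, this is the same kind of change as the one from compound 2 to compound 1, but the place is not identical: there the change sat on a saturated chain carbon bound to an aromatic nitrogen, here on a saturated chain carbon three bonds along the chain from an aromatic nitrogen. Since the earlier step stayed within the scatter, the step from compound 3 to compound 4 is expected to be small as well, about a number 3 percentage points lower from compound 3 to compound 4 (within the scatter). Compound 4 is therefore estimated at 15%, within a range from 6% to 25%.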

Compound 4, a percentage reported as activity, at one concentration (the size of the read-out at that concentration, not a potency): 16%
Estimate against measurement, compound 4: 1 percentage points below; low and high end bracket the measured number.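

In this assay, putting cyano in place of cyanomethyl on the chain gives a number 2 percentage points lower from compound 3 to compound 4 (within the scatter). Set beside the earlier step, this shows the change carrying from one core to the other with no discernible difference in its size: the same change on two cores in this assay, a number 4 percentage points lower (within the scatter) from compound 2 to compound 1 and a number 2 percentage points lower (within the scatter) from compound 3 to compound 4, 2 percentage points apart, within the scatter of two such steps. Neither step rises above the usual scatter, however, so the two pairs do not show that the change has a real effect on either core, and they cannot speak for any core beyond these two.

The compounds shown leave open whether a different group at the end of the chain, such as a carboxylic acid or an amine in place of the nitrile, or a chain longer than 4-cyanobutyl, would shift this read-out. As far as these compounds go, all four compounds also carry the same four bromines, so it remains open how the read-out would respond to chlorine in their place or to a core with fewer bromines.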